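The source may hold more compounds than are shown below. What is called first, only, known or untested is meant among the compounds shown, and "the series" means these compounds.

Series notes. Within the data shown here, in a functional assay on MDA-MB-231 cells (Homo sapiens) for inhibition, read by MTT assay, with a stated time of 48 h (on this read-out lower numbers stand for stronger inhibition and higher numbers for weaker inhibition), compound 1 `COc1cc(-c2cc(/C=C/C(C)=O)[nH]n2)cc(OC)c1OC` gives 27300 nM, the highest of the three numbers measured so far. Compound 2 `COc1ccc(-c2cc(/C=C/C(=O)c3cc(OC)c(OC)c(OC)c3)[nH]n2)cc1OC` gives 2000 nM in this assay, and compound 3 `COc1ccc(-c2cc(/C=C/C(=O)c3ccc(N)cc3)[nH]n2)cc1` gives 1700 nM there; both differences from compound 1 lie beyond the scatter, so compound 1 is the least potent of the three. Compound 4 `COc1cc(-c2cc(/C=C/C(=O)c3ccc(F)c(F)c3)[nH]n2)cc(OC)c1OC` has not yet been measured. Relative to compound 1 the change is 3,4-difluorophenyl in place of methyl on a carbonyl carbon. An aromatic ring on the carbonyl carbon is already present in compound 2 at 2000 nM and in compound 3 at 1700 nM, so a step toward lower numbers, beyond the scatter, is expected. Compound 4 is expected at 2500 nM in this assay, within 800 nM to 8000 nM. The expected step from compound 1 to compound 4 is an 11-fold lower number from compound 1 to compound 4 (1.04 log units; beyond the scatter).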

Compound 4, half-maximal inhibitory concentration: 1500 nM
The estimate for compound 4 lay 1.7-fold (0.22 log units) above the measured number, within the range that was stated.
By their numbers in this assay, from the lowest: compounds 4, 3 and 2 (each within the scatter of the next); then compound 1.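

In this assay, among these compounds, the step of an 18-fold lower number from compound 1 to compound 4 (1.26 log units; beyond the scatter) gives the first reading at this position with the rest of the structure held constant, since the earlier compounds differ from one another in more than one place. It shows that the carbonyl carbon tolerates a far larger group than methyl, with a large change in the number and no loss. Nothing available explains this step. Still open, on these data alone, is whether the ring alone or its two fluorine atoms account for the step. An unsubstituted phenyl or a longer alkyl chain on the carbonyl carbon would separate these possibilities.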